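Swapping an aromatic cap for a short acid chain

The source may hold more compounds than are shown below. What is called first, only, known or untested is meant among the compounds shown, and "the series" means these compounds.

Measured compounds:
- compound 1, `O=C(c1ccccc1)N1CCC(NS(=O)(=O)c2cc(S(=O)(=O)c3ccccc3)ccc2C(F)(F)F)CC1`, 250 nM
- compound 2, `O=C(c1ccc(C(F)(F)F)cc1)N1CCC(NS(=O)(=O)c2cc(S(=O)(=O)c3ccccc3)ccc2C(F)(F)F)CC1`, 970 nM
- compound 3, `O=S(=O)(NC1CCN(S(=O)(=O)c2ccccc2)CC1)c1cc(S(=O)(=O)c2ccccc2)ccc1C(F)(F)F`, 210 nM

In an assay on U2OS cells for inhibition of secreted frizzled-related protein 1 (Homo sapiens), read by a luciferase reporter, with a stated time of 18 h (a lower number here means that less compound is needed, a higher number that more compound is needed for the effect), compound 3 gives the lowest number of the three, yet the step of a 1.2-fold lower number from compound 1 to compound 3 (0.08 log units; within the scatter) lies within the scatter, so the two cannot be ranked. Only compound 2 stands clearly apart: a 4.6-fold lower number from compound 2 to compound 3 (0.66 log units; beyond the scatter).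

Compound 4, `O=C(O)CCCC(=O)N1CCC(NS(=O)(=O)c2cc(S(=O)(=O)c3ccccc3)ccc2C(F)(F)F)CC1`, differs from compound 3 by (3-carboxypropyl)carbonyl in place of phenylsulfonyl on an amine nitrogen in a ring. For the measured compounds named here, none of the measured steps involves this group. The closest hint is that changing the cap on the ring nitrogen between benzoyl and phenylsulfonyl, a 1.2-fold lower number from compound 1 to compound 3 (0.08 log units; within the scatter), hardly matters, while adding trifluoromethyl to that cap, a 3.9-fold higher number from compound 1 to compound 2 (0.59 log units; beyond the scatter), raises the number. A chain with an acid is a larger departure than either, so the outcome is uncertain, and a somewhat higher number is expected for compound 4 in this assay, a 2.9-fold higher number from compound 3 to compound 4 (0.46 log units; beyond the scatter), with a wide range. Compound 4 is expected to give 600 nM, between 150 nM and 3000 nM.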

Compound 4, half-maximal effective concentration: 570 nM
Compound 4: middle estimate off by 1.1-fold (0.02 log units), on the high side; the measured number falls inside the stated range.
By their numbers in this assay, from the lowest: compounds 3 and 1 (each within the scatter of the next); then compounds 4 and 2 (each within the scatter of the next).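

In this assay, the cap on the ring nitrogen need not carry an aromatic ring for the compound to act, although 3-carboxypropyl on the carbonyl comes at a modest cost against the two plain aromatic caps: a 2.7-fold higher number from compound 3 to compound 4 (0.43 log units; beyond the scatter) and a 2.3-fold higher number from compound 1 to compound 4 (0.36 log units; beyond the scatter). Against the cap bearing trifluoromethyl, the picture differs: with a 1.7-fold lower number from compound 2 to compound 4 (0.23 log units; within the scatter), the 3-carboxypropyl and 4-(trifluoromethyl)phenyl groups cannot be ranked. Nothing measured here accounts for these steps.

On these data alone, what stays open is whether the size of the step follows from the carboxylic acid itself or from the chain that carries it. A methyl ester or a plain alkyl chain, a shorter or longer acid chain, or an amine at the chain end would help separate the two.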